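The source may report more compounds than this note shows. Statements on the series, on what has been measured and on what is new or still open speak of the compounds shown alone.

Working notes on the series.

Compound 1 `Cc1nnc2nnc(N3CCCC3)nn12` carries a methyl on the shared core. In a functional assay on MCF7 cells (Homo sapiens) for cytotoxicity, read by MTT assay, with a stated time of 72 h (on this read-out higher numbers stand for weaker inhibition and lower numbers for stronger inhibition), compound 1 gives 44800 nM, the higher of the two numbers recorded for this assay; the nearest neighbour is compound 2 `C1CCC(c2nnc3nnc(N4CCCC4)nn23)CC1`, which in this assay gives 37700 nM. The step from the methyl to the cyclohexyl a 1.2-fold lower number from compound 1 to compound 2 (0.07 log units; within the scatter) stays within the scatter. Compound 3 `O=[N+]([O-])c1ccc(-c2nnc3nnc(N4CCCC4)n3n2)cc1` carries a nitrophenyl at the same site and in this assay reaches only a limit, > 100000 nM, so it provides no number; that limit is the one at which one of the three values sits (the limit of > 100000 nM in this assay, at which 1 of the 3 values shown sits).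

Compound 4 `CC(C)c1nnc2nnc(N3CCCC3)nn12` is the next member to be measured. It differs from compound 1 by isopropyl in place of methyl on an aromatic carbon. Going by the values given here, the only measured step that bears on this change is the one from methyl to cyclohexyl at the same aromatic carbon a 1.2-fold lower number from compound 1 to compound 2 (0.07 log units; within the scatter), which was within the scatter; the isopropyl lies, by size, between these two groups. No step beyond the scatter is therefore expected in this assay, in either direction. The estimate for compound 4 in this assay is 42000 nM, with a range from 15000 nM to 100000 nM, which corresponds to an expected step of a 1.1-fold lower number from compound 1 to compound 4 (0.03 log units; within the scatter) that stays within the scatter.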

Compound 4, half-maximal inhibitory concentration: 46800 nM
For compound 4 the middle estimate is 1.1-fold (0.05 log units) below the measured one, within the range that was stated.
By their numbers in this assay, from the lowest: compounds 2, 1 and 4 (each within the scatter of the next). At a limit, above all of these: compound 3.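

In this assay the series now holds three alkyl groups on the same aromatic carbon, and the new compound gives two steps: a 1.0-fold higher number from compound 1 to compound 4 (0.02 log units; within the scatter) for isopropyl in place of methyl, and a 1.2-fold higher number from compound 2 to compound 4 (0.09 log units; within the scatter) for isopropyl in place of cyclohexyl. Going by these compounds alone, the single step seen earlier is thus no longer alone: across compound 1, compound 2 and compound 4, no change among methyl, isopropyl and cyclohexyl at this position leaves the scatter, so these three groups cannot be told apart on this read-out. Nothing given here accounts for this flat response.

Compound 3 stands at a limit of the assay and not at a number, so its steps to the other compounds cannot be read: the limit of > 100000 nM in this assay, at which 1 of the 4 values shown sits. Going by these compounds, whether a phenyl without the nitro group, an amine, a carboxylic acid or a longer chain on this aromatic carbon would give a step beyond the scatter stays open.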